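Pyridinecarbonyl Replaced by Ethyl on Two Related Cores

The source may report more compounds than this note shows. Statements on the series, on what has been measured and on what is new or still open speak of the compounds shown alone.

The study covers four compounds on two related cores, all examined in a functional assay on A549 cells (Homo sapiens) for antiproliferative activity, read by MTT assay, with a stated time of 48 h; a lower number here means a stronger inhibitor, a higher number a weaker inhibitor. Compound 1 `Cn1cc(-c2cnc3ccc(NC(=O)c4cccnc4)nc3c2)cn1` carries an amide on the first core. In this assay compound 1 gives > 50000 nM, which is a limit of the assay and not a number. Compound 2 `CCNc1ccc2ncc(-c3cnn(C)c3)cc2n1` differs from compound 1 by ethyl in place of (pyridin-3-yl)carbonyl on a nitrogen on an aromatic ring. In this assay compound 2 likewise gives only a limit, > 50000 nM. The step that the two limits leave unreadable from compound 1 to compound 2 is therefore of unknown size. Compound 3 `Cn1cc(-c2cnc3ccnc(NC(=O)c4cccnc4)c3c2)cn1` is built from the same atoms as compound 1, joined differently; the difference between the two cores is not broken down here. In this assay compound 3 gives > 50000 nM, again a limit. Among the compounds with values here, every value so far sits at the limit of > 50000 nM in this assay, at which 3 of the 3 values shown sit, so none of the three can be called stronger or weaker than another.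

Compound 4 `CCNc1nccc2ncc(-c3cnn(C)c3)cc12` has not yet been measured. It differs from compound 3 by ethyl in place of (pyridin-3-yl)carbonyl on a nitrogen on an aromatic ring, the same change that leads from compound 1 to compound 2. Compound 2 gives > 50000 nM in this assay, a limit. On that basis compound 4 is expected to give about 60000 nM in this assay, estimated to lie between 20000 nM and 200000 nM, most probably reported only as a limit. The estimated step that the limit leaves unreadable from compound 3 to compound 4 stands beside the earlier step that the two limits leave unreadable from compound 1 to compound 2, which the two limits leave unreadable.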

Compound 4, half-maximal inhibitory concentration: 40700 nM
Beside the measured number, compound 4's estimate is 1.5-fold (0.17 log units) above it; measured number inside the range.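

In this assay, within the data shown here, compound 4 gives 40700 nM, the only measured number among the four compounds, and ethyl in place of (pyridin-3-yl)carbonyl on this core gives an at least 1.2-fold lower number from compound 3 to compound 4 (0.08 log units; that floor lies within the scatter). That step rests on a limit, the value for compound 3, so it is a floor and not a size: the true step could be larger, but as printed it does not show that the change makes a real difference on this core. The same change on the core of compound 1 cannot be read, so the series does not show whether the change carries from one core to the other with a similar size, or with any effect at all, because nearly all the values sit at one limit: the limit of > 50000 nM in this assay, at which 3 of the 4 values shown sit.

Going by these compounds, it remains open whether a longer chain on the same nitrogen, such as propyl or butyl, or a chain ending in an amine, would bring the number clearly under the limit on either core. On these data alone, the rest of the molecule is the same on both cores, so what a carboxylic acid or an amine elsewhere on the shared core would do also stays open.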